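The source may hold more compounds than are shown below. What is called first, only, known or untested is meant among the compounds shown, and "the series" means these compounds.

Compound 1, `NC(=O)c1cnc(C(=O)CCc2ccc(Oc3ccccc3)cc2)o1`: 6.6 nM
Compound 2, `O=C(O)c1cccc(-c2cnc(C(=O)CCc3ccc(-c4ccc(CN5CCCCC5)cc4)cc3)o2)n1`: 44 nM
Compound 3, `O=C(O)c1ccc(-c2cnc(C(=O)CCc3ccc(COc4ccccc4)cc3)o2)nc1`: 4.6 nM

Of the compounds shown here, three that share the same core have been tested in an assay for inhibition of Fatty-acid amide hydrolase 1 (Rattus norvegicus); on this read-out lower numbers stand for stronger inhibition and higher numbers for weaker inhibition. Compound 1 gives 6.6 nM, the second highest of the three numbers. Compound 3, with 4.6 nM, lies closest to it, and the gap between the two sits within the usual scatter of the measurement. Compound 2, with 44 nM, stands furthest away, and its number is higher than that of compound 1 by more than the scatter allows.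

Compound 4, `COC(=O)c1ccc(-c2cnc(C(=O)CCc3ccc(Oc4ccccc4)cc3)o2)nc1`, has not yet been measured in this assay. It is built from compound 1 by a single change: 5-(methoxycarbonyl)pyridin-2-yl in place of carbamoyl on an aromatic carbon. Among the compounds with values here, no measured pair in this set shows this particular exchange, so the expectation for compound 4 rests on the spread of the three numbers alone. Compound 3 carries a related pyridin-2-yl group on the same core and gives 4.6 nM, a number close to that of compound 1. The step from compound 1 to compound 4 is therefore expected to be small, a 1.3-fold lower number from compound 1 to compound 4 (0.12 log units; within the scatter), and to stay within the scatter. Compound 4 is estimated to give about 5 nM in this assay, with a likely range from 1.5 nM to 20 nM.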

Compound 4, inhibition constant: 54 nM
Estimate against measurement, compound 4: 11-fold (1.03 log units) below; the whole stated range lies below it.
By their numbers in this assay, from the lowest: compounds 3 and 1 (each within the scatter of the next); then compounds 2 and 4 (each within the scatter of the next).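

In this assay, the exchange at this position, on the aromatic carbon next to the ring oxygen, gives an 8.2-fold higher number from compound 1 to compound 4 (0.91 log units; beyond the scatter), the first single-place change the set offers. It shows that, with the rest of compound 1 held fixed, this position does not accept 5-(methoxycarbonyl)pyridin-2-yl as an equal replacement for carbamoyl, although the step ties together several differences: a six-membered aromatic ring enters, the heavy-atom count rises, and the hydrogen-bond donor of carbamoyl is gone. No measurement bears on why the number rises, and the step alone cannot assign it to any one of these differences.

The compounds shown leave open whether the rise belongs to the pyridin-2-yl ring itself or to its methyl ester, since no compound with the core of compound 1 carries a bare pyridin-2-yl group or a carboxylic acid in place of that ester. Also open, on these data alone, is how a smaller group at this position, such as a nitrile or a plain methyl ester directly on the ring, would compare with carbamoyl.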